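Chloro at the Sulfonyl Aryl Ring: From Compound 3 to Compound 4

The source may hold more compounds than are shown below. What is called first, only, known or untested is meant among the compounds shown, and "the series" means these compounds.

The set rests on a shared core carried by compound 1 `CCOc1ccc(F)cc1C(C)NC(=O)NS(=O)(=O)c1ccc(Cl)cc1`, compound 2 `COc1ccc(F)cc1C(C)NC(=O)N(C)S(=O)(=O)c1ccc(Cl)cc1`, compound 3 `COc1ccc(F)cc1C(C)NC(=O)NS(=O)(=O)c1ccccc1` and the unmeasured compound 4 `COc1ccc(F)cc1C(C)NC(=O)NS(=O)(=O)c1ccc(Cl)cc1`. In a functional assay on thoracic aorta (Rattus norvegicus, strain Wistar), with a stated time of 15 min (a lower number here means that less compound is needed, a higher number that more compound is needed for the effect), compound 3 gives only a limit, > 300000 nM, and not a number. In this assay compound 1 likewise gives only a limit, > 300000 nM. Compound 3 therefore stands at the limit of > 300000 nM in this assay, at which 2 of the 3 values shown sit, so nothing of its own value is known beyond that bound. Compound 2, which carries a methyl on the sulfonyl nitrogen, gives 12600 nM in this assay.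

Compound 4 arises from compound 3 by one change: chloro in place of hydrogen on an aromatic carbon. For the measured compounds named here, no measured step joins two compounds of this set, so the size of the step is open. Since compound 1 and compound 3 both sit at the limit and only compound 2 gives a number, compound 4 is expected to remain weak, with an estimated value of 150000 nM (20000 nM to 300000 nM). The expected step of an at least 2.0-fold lower number from compound 3 to compound 4 (0.30 log units; that floor lies within the scatter) is thus estimated as small and uncertain, and a further limit is as likely as a number.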

Compound 4, half-maximal effective concentration: > 300000 nM
Compound 4 ended at the assay's limit; the forecaster's own chance of this, stated with the estimate: 55%; middle value at least 2.0-fold (0.30 log units) away from the limit.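

In this assay, compound 4 with its 4-chlorophenyl group sits at the assay's limit, as compound 3 with its phenyl does, so chloro in place of hydrogen on this aromatic carbon yields no number. The steps that link compound 4 to compound 3 and to compound 1 cannot be read, since both ends of each are limits. The new information lies at the amide-type nitrogen instead, where hydrogen in place of methyl gives an at least 23-fold higher number from compound 2 to compound 4 (1.37 log units; beyond the scatter), and compound 2 remains the only compound with a number: the limit of > 300000 nM in this assay, at which 3 of the 4 values shown sit.

For the compounds shown here, what chloro does on this aromatic carbon stays open, since the only comparison for it ends in two limits. As far as these compounds go, it is also open whether a longer chain such as ethyl on the amide-type nitrogen would give a number as the methyl of compound 2 does.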